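A few compounds are considered here, and "the series" means these few. Any claim that something is new, unique, unknown or untested is made for them only; others in the source may bear on it.

Measured in a functional assay on the whole organism with Rattus norvegicus as the target; on this read-out lower numbers stand for an effect already at smaller amounts and higher numbers for an effect only at larger amounts of compound:
Compound 1 `Cn1c(=N)sc2cc(OC(F)(F)F)ccc21`: 5 mg/kg
Compound 2 `C=CCn1c(=N)sc2cc(OC(F)(F)F)ccc21`: 7 mg/kg
Compound 3 `N=c1sc2cc(OC(F)(F)F)ccc2n1CC(=O)O`: > 10 mg/kg (a limit)

Compound 3 has no number, only (the limit of > 10 mg/kg in this assay, at which 1 of the 3 values shown sits). Compound 4 `CCN(CC)C(=O)Cn1c(=N)sc2cc(OC(F)(F)F)ccc21` differs from it at one place: diethylamino in place of hydroxy on a carbonyl carbon. This puts diethylamino in place of hydroxy on a carbonyl carbon, turning carboxy into diethylcarbamoyl.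

Among the compounds with values here, the steps that bear on this are an at least 2.0-fold higher number from compound 1 to compound 3 (0.30 log units; that floor lies within the scatter) and an at least 1.4-fold higher number from compound 2 to compound 3 (0.15 log units; that floor lies within the scatter), and beside them a 1.4-fold higher number from compound 1 to compound 2 (0.15 log units; within the scatter). With the carboxy gone, a number near compound 1 at 5 mg/kg and compound 2 at 7 mg/kg is expected. The expected change is small and downward, an at least 1.4-fold lower number from compound 3 to compound 4 (0.15 log units; that floor lies within the scatter), and it may not clear the scatter. For compound 4 the estimate is 7 mg/kg, with an expected range of 2.5 mg/kg to 20 mg/kg.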

Compound 4, dose for half-maximal effect: 9 mg/kg
Beside the measured number, compound 4's estimate is 1.3-fold (0.11 log units) below it; the measured number falls inside the stated range.
By their numbers in this assay, from the lowest: compounds 1, 2 and 4 (each within the scatter of the next). At a limit, above all of these: compound 3.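

With diethylcarbamoyl on the saturated chain carbon bound to an aromatic nitrogen, this assay shows a 1.8-fold higher number from compound 1 to compound 4 (0.26 log units; within the scatter) and a 1.3-fold higher number from compound 2 to compound 4 (0.11 log units; within the scatter) and so does not separate this group from hydrogen or vinyl at this place. Compound 3 has only a limit, not a number: the limit of > 10 mg/kg in this assay, at which 1 of the 4 values shown sits. Turning carboxy into diethylcarbamoyl thus gives only an at least 1.1-fold lower number from compound 3 to compound 4 (0.04 log units; that floor lies within the scatter) and the true size of this change cannot be read. As far as these compounds go, whether a methyl ester or primary amide on the same carbonyl carbon, or an amine on the chain, would stand clear of the scatter stays open.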